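The source may report more compounds than this note shows. Statements on the series, on what has been measured and on what is new or still open speak of the compounds shown alone.

Three compounds have so far been measured in a functional assay on MCF7 cells (Homo sapiens) for cytotoxicity, read by neutral red uptake, with a stated time of 3 days; on this read-out higher numbers stand for weaker inhibition and lower numbers for stronger inhibition:
Compound 1, `Nc1ccc(-c2cc(=O)c3c(N)c(F)cc(F)c3o2)cc1F`, gives 40 nM.
Compound 2, `C[S+]([O-])c1c(F)c(N)c2c(=O)cc(-c3ccc(N)c(F)c3)oc2c1F`, gives 2500 nM.
Compound 3, `CCCCCCCCCC(=O)OCc1c(F)c(N)c2c(=O)cc(-c3ccc(N)c(F)c3)oc2c1F`, gives 100 nM.

Compound 1 stands lowest of the three numbers and is the strongest inhibitor here; compound 3 comes nearest, with a higher number that lies beyond the scatter, and compound 2 lies furthest away. Within the data shown here, the one step between compounds that differ in a single place is a 63-fold higher number from compound 1 to compound 2 (1.80 log units; beyond the scatter), in which a group of 3 heavy atoms (1 carbon, 1 oxygen, 1 sulfur; no ring) takes the place of a hydrogen atom on an aromatic carbon.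

Compound 4, `CCCCCCOCc1c(F)c(N)c2c(=O)cc(-c3ccc(N)c(F)c3)oc2c1F`, has not yet been measured. It differs from compound 1 by (hexyloxy)methyl in place of hydrogen on an aromatic carbon, a chain entering at the aromatic carbon ortho to two fluoro groups. That step to compound 2 was large, but compound 3, which carries a long chain at that same carbon, shows a number only somewhat above compound 1. Compound 3 is taken as the closer guide, so a modest rise is expected: a 2.5-fold higher number from compound 1 to compound 4 (0.40 log units; beyond the scatter). Compound 4 is therefore estimated at 100 nM, with a range from 40 nM to 300 nM.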

Compound 4, half-maximal inhibitory concentration: 7100 nM
Compound 4: the middle estimate sits 71-fold (1.85 log units) below what was measured; measured number above the stated range.
By their numbers in this assay, from the lowest: compound 1; then compound 3; then compound 2; then compound 4.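

The (hexyloxy)methyl chain at this aromatic carbon, ortho to two fluoro groups, brings a 180-fold higher number from compound 1 to compound 4 (2.25 log units; beyond the scatter), so a chain here does not by itself keep the number close to that of compound 1. What sits on the chain's oxygen matters greatly: hexyl in place of nonylcarbonyl brings a 71-fold higher number from compound 3 to compound 4 (1.85 log units; beyond the scatter), so these two chains on the same carbon cannot stand in for each other. The step from the group in compound 2 is much smaller, at a 2.8-fold higher number from compound 2 to compound 4 (0.45 log units; beyond the scatter), and all three groups shown at this carbon give higher numbers than hydrogen does, by very different amounts.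

The compounds shown offer no measurement that explains these differences. On these data alone, it remains open where a shorter chain such as methoxymethyl, a hydroxymethyl group or a carboxylic acid at this carbon would fall.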